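The compounds below may be only part of what the source reports. "The series", "measured", "known", "first", "only" and "open" are said of these compounds alone.

Measured so far:
compound 1 `O=C(Nc1cccnc1)c1cccnc1` — in an assay on V79 cells for inhibition of cytochrome P450 11B1, mitochondrial (Homo sapiens), tested at 500 nM (on this read-out higher numbers stand for more inhibition at the one concentration tested (going by the name of the read-out) and lower numbers for less inhibition), compound 1 gives 3%
compound 2 `O=C(Nc1cccnc1)c1ccc(Cl)cc1` — in this assay compound 2 gives 5%

Compound 2 holds the top figure of the two, but the gap to compound 1 lies within the scatter, so the two compounds cannot be told apart; both numbers are low. Compound 3 `Cc1ccc(C(=O)Nc2cccnc2)cc1` differs from compound 2 by methyl in place of chloro on an aromatic carbon. Going by the values given here, no step between measured compounds is available to gauge this change, and no step beyond the scatter is expected in this assay. Compound 3 is expected to give about 5% in this assay, with a range of 0% to 15%. The estimated step of no change at the digits printed from compound 2 to compound 3 (within the scatter) is expected to stay within the scatter.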

Compound 3, a percentage reported as inhibition, at one concentration (the size of the read-out at that concentration, not a potency): 0%
Compound 3: middle estimate off by 5 percentage points, on the high side, and the stated range covers the measured number.
By their numbers in this assay, from the lowest: compounds 3, 1 and 2 (each within the scatter of the next).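

In this assay the exchange of chloro for methyl on an aromatic carbon gives a number 5 percentage points lower from compound 2 to compound 3 (within the scatter) and so shows no readable effect of this change. At this position, para to a group of 9 heavy atoms, these two groups cannot be told apart on this read-out. No measurement on hand bears on the result.

Going by these compounds, whether an amine, a carboxylic acid or a longer chain at this position would give a number beyond the scatter stays open. So does whether any other place on the core of compound 2 responds to substitution.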